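Methoxy to chloro on the benzyl ether, thione series

The compounds below may be only part of what the source reports. "The series", "measured", "known", "first", "only" and "open" are said of these compounds alone.

Two compounds carry numbers. Compound 1 `Cc1ccc(COc2ccc(-c3nn(CCC#N)c(=O)o3)cc2)cc1` gives 15 nM in an assay for inhibition of Amine oxidase [flavin-containing] B (Rattus norvegicus); a higher number here means a weaker inhibitor, a lower number a stronger inhibitor. Among the compounds with values here, compound 2 `COc1ccc(COc2ccc(-c3nn(CCC#N)c(=S)o3)cc2)cc1` gives 910 nM in this assay, the highest of the two numbers and beyond the scatter from compound 1; the two differ in more than one place, so no single step is drawn between them. Compound 3 `N#CCCn1nc(-c2ccc(OCc3cccc(Cl)c3)cc2)oc1=S` brings (3-chlorophenyl in place of 4-methoxyphenyl on a saturated chain carbon bound to an oxygen on an aromatic ring). Within the data shown here, no step of this kind has been measured, so the expected step of a 1.8-fold lower number from compound 2 to compound 3 (0.26 log units; within the scatter) is small, toward a lower number, with little confidence. Compound 3 is estimated at 500 nM, with a range from 100 nM to 3000 nM.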

Compound 3, half-maximal inhibitory concentration: 160 nM
Compound 3: the middle estimate sits 3.1-fold (0.49 log units) above what was measured, and the stated range covers the measured number.
By their numbers in this assay, from the lowest: compound 1; then compound 3; then compound 2.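

On a saturated chain carbon bound to an oxygen on an aromatic ring, 3-chlorophenyl in place of 4-methoxyphenyl moves the number in this assay beyond the scatter (a 5.7-fold lower number from compound 2 to compound 3 (0.75 log units; beyond the scatter)), so this place is not indifferent to the aryl group in the thione compounds. The substituent and its ring position change together, and this single step cannot separate the two. No measurement at hand bears on the reason for the shift.

Open, on these data alone, is whether 4-chlorophenyl or 3-methoxyphenyl would separate these two changes. Also open, as far as these compounds go, is whether 3-chlorophenyl gives a similar step on the core of compound 1.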